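Isopropylamino replacing pyrrolidinyl on the shared core

The compounds below may be only part of what the source reports. "The series", "measured", "known", "first", "only" and "open" are said of these compounds alone.

Measured compounds:
compound 1, `CCCCSc1nc(N)nc2c1ncn2/C=C1/CC1(CO)CO`, 89000 nM
compound 2, `CCCOc1nc(N)nc2c1ncn2/C=C1/CC1(CO)CO`, > 20000 nM
compound 3, `Nc1nc(N2CCCC2)c2ncn(/C=C3/CC3(CO)CO)c2n1`, > 20000 nM

In an ADME assay on CCRF-HSB-2 cells (Homo sapiens) for cytotoxicity, with a stated time of 7 days (a lower number here means that less compound is tolerated, a higher number that more compound is tolerated), compound 1 gives 89000 nM. For compound 2 the value > 20000 nM is a limit of the assay, not a number. For compound 3 the value > 20000 nM is likewise a limit. Compound 3 therefore stands at the cut-off of the assay, and the steps a step that the limit leaves unreadable from compound 1 to compound 3 and a step that the two limits leave unreadable from compound 2 to compound 3 cannot be sized, the point being (the limit of > 20000 nM in this assay, at which 2 of the 3 values shown sit).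

Compound 4, `CC(C)Nc1nc(N)nc2c1ncn2/C=C1/CC1(CO)CO`, is the compound not yet measured. The change is isopropylamino in place of pyrrolidin-1-yl on an aromatic carbon. No measured step bears on it directly: the steps to compound 3 are unreadable, and the step that the limit leaves unreadable from compound 1 to compound 2 is unreadable for the same reason. Going by the values given here, what remains is that compound 1, the one readable value, shows a high tolerated concentration, and the two other compounds sit at the limit.

Compound 4 is therefore expected to stay in the same weakly cytotoxic region, estimated at 60000 nM (range 20000 nM to 200000 nM), with the step that the limit leaves unreadable from compound 3 to compound 4 expected to be unreadable beyond the scatter, and most likely reported again as a limit.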

Compound 4, half-maximal cytotoxic concentration: > 20000 nM
Compound 4: a limit, no number (the forecaster's own chance of this, stated with the estimate: 75%); the middle value lies beyond the limit too.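

In this assay compound 4 gives > 20000 nM, which is a limit and not a number. The steps from compound 1, compound 2 and compound 3 to compound 4 therefore cannot be read: the limit of > 20000 nM in this assay, at which 3 of the 4 values shown sit. The compounds shown leave open how far compound 2, compound 3 and compound 4 actually lie from one another and from compound 1.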